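Amine swap from compound 1 to compound 4

A few compounds are considered here, and "the series" means these few. Any claim that something is new, unique, unknown or untested is made for them only; others in the source may bear on it.

In a functional assay on A2780 cells (Homo sapiens) for antiproliferative activity, read by MTT assay, with a stated time of 72 h (a higher number here means a weaker inhibitor, a lower number a stronger inhibitor), compound 1 (`CC(C)NC(=N)NC(=N)Nc1ccc(C(F)(F)F)cc1`) gives 3200 nM, the second highest of the three numbers. Compound 2 (`CC(C)CNC(=N)NC(=N)Nc1ccc(F)c(F)c1`) stands higher at 6700 nM, and compound 3 (`CCCCCCCNC(=N)NC(=N)Nc1ccc(F)c(F)c1`) stands lower at 1500 nM.

Compound 4 (`CCN(C)C(=N)NC(=N)Nc1ccc(C(F)(F)F)cc1`) has the same atoms as compound 1, joined differently: ethyl(methyl)amino in place of isopropylamino on a carbon with a double bond to nitrogen. Ethyl(methyl)amino takes the place of isopropylamino on a carbon with a double bond to nitrogen.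

Within the data shown here, the only measured step that touches this end of the molecule is a 4.5-fold lower number from compound 2 to compound 3 (0.65 log units; beyond the scatter), which is modest. Among the measured compounds shown here, it is an indirect guide, since its core differs from the core of compound 1 and no measured compound carries ethyl(methyl)amino. Only a small shift is therefore expected in this assay, tentatively toward a higher number. The estimated step is a 1.5-fold higher number from compound 1 to compound 4 (0.18 log units; within the scatter). For compound 4 the estimated value is 4800 nM, with an expected range of 1800 nM to 12000 nM.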

Compound 4, half-maximal inhibitory concentration: 5100 nM
The estimate for compound 4 lay 1.1-fold (0.03 log units) below the measured number; measured number inside the range.
By their numbers in this assay, from the lowest: compound 3; then compounds 1, 4 and 2 (each within the scatter of the next, the first and the last beyond it).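

In this assay, the swap on the core of compound 1 gives a 1.6-fold higher number from compound 1 to compound 4 (0.20 log units; within the scatter), the first step read directly at this place on that core. Isopropylamino carries one hydrogen-bond donor and ethyl(methyl)amino carries none, yet with the heavy-atom count unchanged the step stays within the scatter, so this assay does not separate the two groups on a carbon with a double bond to nitrogen. Nothing available here bears on the reason for this result.

On these data alone, whether the same tolerance holds for dimethylamino or diethylamino on the shared core remains open. A longer chain such as hexyl in place of isopropyl on the core of compound 1 would show whether the step seen on the other core, a 4.5-fold lower number from compound 2 to compound 3 (0.65 log units; beyond the scatter), carries over.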